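Fluoro for methoxy on the aryl ring, compound 3 to compound 4

The compounds below may be only part of what the source reports. "The series", "measured", "known", "first", "only" and "open" are said of these compounds alone.

Compound 3 `CCC(C(=O)N1CCN(c2cccc(OC)c2)CC1)N1C(=O)CCC1=O` gives 0% in a functional assay on the whole organism (strain Swiss) with Mus musculus as the target, in the maximal electroshock model, with a stated time of 2 h, at a dose of 300 mg/kg by the intraperitoneal route; a lower number here means a weaker effect, a higher number a stronger effect of the compound at the dose given. Compound 1 `COc1cccc(N2CCN(C(=O)C(C)N3C(=O)CCC3=O)CC2)c1` gives 0% in this assay, and compound 2 `CCC(C(=O)N1CCN(c2ccccc2Cl)CC1)N1C(=O)CCC1=O` gives 0%, so compound 3 stands level with both at the digits shown; no compound in the set shows any effect at this dose. The two measured steps are no change at the digits printed from compound 1 to compound 3 (within the scatter) and no change at the digits printed from compound 2 to compound 3 (within the scatter); neither a methyl on the chain carbon nor a swap of the aryl group moved the read-out.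

Compound 4 `CCC(C(=O)N1CCN(c2cccc(F)c2)CC1)N1C(=O)CCC1=O` differs from compound 3 by fluoro in place of methoxy on an aromatic carbon. The step from compound 2 to compound 3 bears most directly on this change, as it also swaps the aryl group on the ring nitrogen, and it gave no change; the step from compound 1 to compound 3 adds that the series as a whole sits flat. A step of no change at the digits printed from compound 3 to compound 4 (within the scatter) is therefore expected, that is none beyond the scatter. Compound 4 is estimated at 0% in this assay, with a range from 0% to 10%.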

Compound 4, a percentage reported as activity, at one dose (the size of the read-out at that dose, not a potency): 0%
Estimate against measurement, compound 4: no gap at the digits printed; the measured number falls inside the stated range.
By their numbers in this assay, from the lowest: compounds 1, 2, 3 and 4 (each within the scatter of the next).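

In this assay, the aromatic carbon meta to a large group now carries either methoxy or fluoro, and this direct exchange gives no change at the digits printed from compound 3 to compound 4 (within the scatter). The 3-fluorophenyl group also leaves the read-out flat against 2-chlorophenyl, with no change at the digits printed from compound 2 to compound 4 (within the scatter), so a halogen at this position has now been compared with both the 3-methoxyphenyl and 2-chlorophenyl groups without any separation. No measured evidence bears on the reason for this flat result.

With all four compounds level and showing no effect at this dose, the series gives no active reference point for ranking aryl groups. As far as these compounds go, it remains open whether an amine or a carboxylic acid at this aromatic carbon, or a longer chain on the saturated chain carbon, would produce any effect.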